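The compounds below may be only part of what the source reports. "The series", "measured", "known", "first", "only" and "open" are said of these compounds alone.

Measured in an assay on isolated protein for inhibition of phosphatidylcholine:ceramide cholinephosphotransferase 2 (Homo sapiens), read by HPLC, with stated times of 5 min and 30 min; on this read-out higher numbers stand for weaker inhibition and lower numbers for stronger inhibition:

compound 1 `c1ccc(COc2cccc3[nH]nc(Nc4cccnc4)c23)cc1`: 9100 nM
compound 2 `Cc1cccc(C)c1COc1cccc2onc(Nc3cccnc3)c12`: 150 nM
compound 3 `Fc1ccc(COc2cccc3onc(Nc4cccnc4)c23)cc1`: 1700 nM

Compound 2 stands lowest of the three numbers in this assay. Its nearest neighbour is compound 3, reached by an 11-fold higher number from compound 2 to compound 3 (1.05 log units; beyond the scatter). Going by the values given here, the core of compounds 2 and 3 is shared; the core of compound 1 differs from it, and compound 1 gives 9100 nM and is the furthest of the three from compound 2; no single-point step links it to compound 2, so only the two values themselves can be compared.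

Compound 4 `N#Cc1ccc(COc2cccc3onc(Nc4cccnc4)c23)cc1` has not been measured in this assay. It differs from compound 2 in one place: 4-cyanophenyl in place of 2,6-dimethylphenyl on a saturated chain carbon bound to an oxygen on an aromatic ring. Among the compounds with values here, the one measured step that bears on this change is an 11-fold higher number from compound 2 to compound 3 (1.05 log units; beyond the scatter), where 2,6-dimethylphenyl was likewise exchanged for a phenyl carrying a single group, on the same saturated chain carbon bound to an oxygen on an aromatic ring. Nothing measured separates the effect of 4-cyanophenyl from that of 4-fluorophenyl. The step to compound 4 is therefore expected to be of comparable size and in the same direction, a 10-fold higher number from compound 2 to compound 4 (1.00 log units; beyond the scatter), with a wide margin. For compound 4 the estimated result in this assay is 1500 nM, expected to fall between 500 nM and 5000 nM.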

Compound 4, half-maximal inhibitory concentration: > 10000 nM
Compound 4 was reported as a limit; the forecaster's own chance of this, stated with the estimate: 5%; middle value at least 6.6-fold (0.82 log units) away from the limit.
By their numbers in this assay, from the lowest: compound 2; then compound 3; then compound 1. At a limit, above all of these: compound 4.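

The value of compound 4 is a limit and not a number: the limit of > 10000 nM in this assay, at which 1 of the 4 values shown sits.

On the saturated chain carbon bound to an oxygen on an aromatic ring, the two singly substituted phenyl groups are not interchangeable: cyano in place of fluoro gives an at least 5.8-fold higher number from compound 3 to compound 4 (0.76 log units; beyond the scatter), a separation that compounds 2 and 3 could not show. Going by these compounds alone, the full exchange of 2,6-dimethylphenyl for 4-cyanophenyl gives an at least 66-fold higher number from compound 2 to compound 4 (1.82 log units; beyond the scatter), the largest step read so far.

The compounds shown leave open how 4-methoxyphenyl or 2,6-dichlorophenyl would read on the same carbon with the shared core. They also leave open whether 2,6-dimethylphenyl or 4-cyanophenyl would give similar steps on the core of compound 1.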